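Exchanging 2,4-dichlorophenyl for 4-aminophenyl: working notes on the series

The source may hold more compounds than are shown below. What is called first, only, known or untested is meant among the compounds shown, and "the series" means these compounds.

In a functional assay on K562 cells (Homo sapiens) for antiproliferative activity, read by MTT assay, with a stated time of 72 h (on this read-out lower numbers stand for stronger inhibition and higher numbers for weaker inhibition), compound 2 (`COc1cc(-c2ncnn2-c2ccc(Cl)cc2Cl)cc(OC)c1OC`) gives only a limit, > 10000 nM. Compound 1 (`COc1cc(-n2ncnc2-c2ccc(C)cc2)cc(OC)c1OC`) also gives only a limit, > 10000 nM. Going by the values given here, compound 3 (`COc1ccc(-c2ncnn2-c2cc(OC)c(OC)c(OC)c2)cc1`) gives 950 nM, the one true number so far. The data are therefore bounded by the limit of > 10000 nM in this assay, at which 2 of the 3 values shown sit.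

Compound 4 (`COc1cc(-c2ncnn2-c2ccc(N)cc2)cc(OC)c1OC`) departs from compound 2 by 4-aminophenyl in place of 2,4-dichlorophenyl on an aromatic nitrogen. In words, this is 4-aminophenyl in place of 2,4-dichlorophenyl on an aromatic nitrogen, next to the ring atom that bears a large group.

Among the compounds with values here, no measured step covers this exchange. The nearest evidence is an at least 10-fold lower number from compound 1 to compound 3 (1.02 log units; beyond the scatter), a large change beyond the scatter, but it is methoxy in place of methyl on an aromatic carbon and so bears on the present step only indirectly. It does show that one small substituent change can carry a compound from the limit to a measurable number in this assay.

A step toward a lower number is expected, though its size is poorly defined with compound 2 known only as a limit. The expected change is an at least 6.6-fold lower number from compound 2 to compound 4 (0.82 log units; beyond the scatter). For compound 4 the estimated value is 1500 nM, with an expected range from 150 nM to 10000 nM.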

Compound 4, half-maximal inhibitory concentration: > 10000 nM
Compound 4: a limit, no number; the forecaster's own chance of this, stated with the estimate: 35%; middle value at least 6.6-fold (0.82 log units) away from the limit.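

Compound 2 and compound 4 each give only a limit in this assay, so no step can be read for the exchange of 2,4-dichlorophenyl for 4-aminophenyl: the limit of > 10000 nM in this assay, at which 3 of the 4 values shown sit.

The compounds shown leave open how compound 2 and compound 4 compare, and whether this exchange changes the antiproliferative activity at all.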